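The source may hold more compounds than are shown below. What is called first, only, known or untested is meant among the compounds shown, and "the series" means these compounds.

Working notes on the series.

Compound 1 `CN(C)c1ccc(C2CC(c3ccc(-n4cncn4)cc3)=NN2)cc1` carries a hydrogen on the amine nitrogen in the ring of the shared core. In a functional assay on NCI-H1975 cells (Homo sapiens) for inhibition, read by sulforhodamine B assay, tested at 10 uM (on this read-out higher numbers stand for more inhibition at the one concentration tested (going by the name of the read-out) and lower numbers for less inhibition), compound 1 gives -3.3%. Compound 2 `COC(=O)CC(=O)N1N=C(c2ccc(-n3cncn3)cc2)CC1c1ccc(N(C)C)cc1` puts a ((methoxycarbonyl)methyl)carbonyl on that nitrogen, and in this assay compound 2 gives 1.5%, a step of a number 4.8 percentage points higher from compound 1 to compound 2 (within the scatter). Compound 3 `CN(C)c1ccc(C2CC(c3ccc(-n4cncn4)cc3)=NN2C(=O)c2ccc(F)cc2)cc1` puts a (4-fluorophenyl)carbonyl there instead, and in this assay compound 3 gives -1.1%. Compound 3 is the second highest of the three numbers; its step from compound 1 is a number 2.2 percentage points higher from compound 1 to compound 3 (within the scatter), and the step from compound 2 to compound 3 is a number 2.6 percentage points lower from compound 2 to compound 3 (within the scatter). None of the three compounds separates from the others beyond the scatter, so on these numbers the inhibition in this assay cannot be called higher or lower for any one of them.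

Compound 4 `CN(C)c1ccc(C2CC(c3ccc(-n4cncn4)cc3)=NN2C(=O)c2cc(Cl)cc(Cl)c2)cc1` differs from compound 3 in one place: 3,5-dichlorophenyl in place of 4-fluorophenyl on a carbonyl carbon. The step that bears most directly on this change is the exchange on the carbonyl carbon from compound 2 to compound 3, which was a number 2.6 percentage points lower from compound 2 to compound 3 (within the scatter), and both acylations of the ring nitrogen, a number 4.8 percentage points higher from compound 1 to compound 2 (within the scatter) and a number 2.2 percentage points higher from compound 1 to compound 3 (within the scatter), were likewise within the scatter. A step in this assay beyond the scatter is therefore not expected in either direction; the estimated step is a number 1.1 percentage points higher from compound 3 to compound 4 (within the scatter). Compound 4 is expected to give 0% in this assay, with a range from -10% to 12%.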

Compound 4, a percentage reported as inhibition, at one concentration (the size of the read-out at that concentration, not a potency): 8.4%
The estimate for compound 4 lay 8.4 percentage points below the measured number, and the stated range covers the measured number.
By their numbers in this assay, from the lowest: compounds 1, 3, 2 and 4 (each within the scatter of the next, the first and the last beyond it).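

In this assay, among the compounds shown here, the (3,5-dichlorophenyl)carbonyl on the amine nitrogen in the ring gives the first step beyond the scatter (a number 11.7 percentage points higher from compound 1 to compound 4 (beyond the scatter)), modest in size, whereas neither acyl group on that nitrogen in compound 2 or compound 3 separated from the hydrogen of compound 1. The exchanges on the carbonyl carbon remain within the scatter (a number 9.5 percentage points higher from compound 3 to compound 4 (within the scatter)) and (a number 6.9 percentage points higher from compound 2 to compound 4 (within the scatter)), so compound 4 separates from compound 1 only and not from the other two acylated compounds. This position can therefore carry a readable change relative to hydrogen, but 3,5-dichlorophenyl cannot yet be placed apart from 4-fluorophenyl or (methoxycarbonyl)methyl on the carbonyl carbon, and nothing available bears on why the number moves.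

Open, from the compounds shown here alone, is whether one chlorine on the phenyl ring would give a step of the same size as the two in compound 4, or whether a dimethylphenyl would do the same. Also open, going by these compounds, is whether an amine or a carboxylic acid on the acyl group would leave the number in this assay within the scatter of compound 1.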